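The compounds below may be only part of what the source reports. "The series", "measured", "known", "first", "only" and "open" are said of these compounds alone.

In a physicochemical assay for acid dissociation, read by spectrophotometry, compound 1 `Cn1cc(O)c(=O)cc1CN1CCCCC1` gives 2.16, the lowest of the three numbers in hand. Compound 3 `Cc1c(O)c(=O)ccn1CCN(C)C` gives 2.86 and compound 2 `CCc1c(O)c(=O)ccn1CCCn1ccnc1` gives 3.15, each above compound 1 by more than the scatter, though neither differs from it in a single place. Compound 4 `O=c1cc(CN2CCCCC2)n(CCN2CCCCC2)cc1O` differs from compound 1 by one change: (piperidin-1-yl)methyl in place of hydrogen on a saturated chain carbon bound to an aromatic nitrogen. Among the measured compounds shown here, no measured pair shows this change on its own. A modest rise is expected, a number 0.44 log units higher from compound 1 to compound 4 (beyond the scatter) in this assay, given that compound 3 gives 2.86 and compound 2 gives 3.15, both higher than compound 1. Compound 4 is therefore estimated at 2.6, with a range from 2.1 to 3.2.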

Compound 4, acid dissociation constant: 2.04
Estimate against measurement, compound 4: 0.56 log units above, outside the stated range (below it).
By their numbers in this assay, from the lowest: compounds 4 and 1 (each within the scatter of the next); then compounds 3 and 2 (each within the scatter of the next).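

In this assay, among the compounds shown here, the entry of (piperidin-1-yl)methyl in place of hydrogen on a saturated chain carbon bound to an aromatic nitrogen gives a number 0.12 log units lower from compound 1 to compound 4 (within the scatter) and is the first single-place step at this position. Its 7 heavy atoms and six-membered non-aromatic ring therefore enter there without a shift beyond the scatter. No measurement in hand offers an explanation for this result. On these data alone, whether a carboxylic acid or a primary amine on this chain would behave the same way remains open.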